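The source may hold more compounds than are shown below. What is called first, only, known or untested is meant among the compounds shown, and "the series" means these compounds.

Measured so far:
compound 1 `Oc1ccc(-c2cc(-c3ccccc3OC(F)(F)F)cc(-c3ccccc3O)n2)cc1` gives 2050 nM in a functional assay on T47D cells (Homo sapiens) for inhibition; on this read-out lower numbers stand for stronger inhibition and higher numbers for weaker inhibition;
compound 2 `Oc1cccc(-c2cc(-c3ccccc3OC(F)(F)F)cc(-c3cccc(O)c3)n2)c1` gives 7950 nM in this assay.

Of these two numbers, compound 2 stands at the higher one, and the gap to compound 1 lies beyond the usual scatter, so compound 2 is the weaker inhibitor of the pair. Compound 3 `Oc1ccc(-c2cc(-c3ccccc3OC(F)(F)F)cc(-c3cccc(O)c3)n2)cc1` is not yet measured. It differs from compound 2 by 4-hydroxyphenyl in place of 3-hydroxyphenyl on an aromatic carbon. Since compound 1 carries two 4-hydroxyphenyl groups and gives the lower number, a step down from compound 2 is expected, of moderate size, a 2.0-fold lower number from compound 2 to compound 3 (0.30 log units; within the scatter). Compound 3 is therefore estimated at 4000 nM, with a range from 1500 nM to 10000 nM.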

Compound 3, half-maximal inhibitory concentration: 7300 nM
Beside the measured number, compound 3's estimate is 1.8-fold (0.26 log units) below it; the range from low to high includes it.
By their numbers in this assay, from the lowest: compound 1; then compounds 3 and 2 (each within the scatter of the next).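

In this assay, 4-hydroxyphenyl and 3-hydroxyphenyl cannot be told apart at this position: the swap gives a 1.1-fold lower number from compound 2 to compound 3 (0.04 log units; within the scatter). The other single swap reads differently, as 3-hydroxyphenyl in place of 2-hydroxyphenyl gives a 3.6-fold higher number from compound 1 to compound 3 (0.55 log units; beyond the scatter), so among these three compounds only the change involving 2-hydroxyphenyl goes beyond the scatter. Nothing available explains either step. Still open, on these data alone, is what a methoxy group or an amine would do in place of the hydroxyl on these rings, and whether any such compound would give a lower number than compound 1 does.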